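A few compounds are considered here, and "the series" means these few. Any claim that something is new, unique, unknown or untested is made for them only; others in the source may bear on it.

In an ADME assay (liver, Mus musculus) for metabolic stability, read by LC-MS, using microsomes, tested at 1 uM (a lower number here means that the compound disappears faster, a higher number that the compound lasts longer), compound 2 `CC(C)/C(=N/c1ccnc2cc(Cl)ccc12)NCCCCN1CCCCC1` gives 0.517 h, and compound 3 `CCN(CC)CCCCN/C(=N\c1ccnc2cc(Cl)ccc12)C(C)C` gives 0.7 h. Compound 1 `C/C(=N/c1ccnc2cc(Cl)ccc12)NCCCCN1CCCCC1` reaches only a limit of this assay in this assay, > 1 h; the assay stops at the limit of > 1 h in this assay, at which 1 of the 3 values shown sits. The change from compound 2 to compound 1 is methyl in place of isopropyl on a carbon with a double bond to nitrogen, and it brought an at least 1.9-fold higher number from compound 2 to compound 1 (0.28 log units; that floor lies within the scatter). The cores of compound 2 and compound 3 differ by diethylamino in place of piperidin-1-yl on a saturated chain carbon, four bonds along the chain from an amine nitrogen, with a 1.4-fold higher number from compound 2 to compound 3 (0.13 log units; within the scatter). Compound 4 `CCN(CC)CCCCN/C(C)=N\c1ccnc2cc(Cl)ccc12` has not yet been measured. It differs from compound 3 by methyl in place of isopropyl on a carbon with a double bond to nitrogen, the same change as from compound 2 to compound 1. Beside that earlier step, the step from compound 3 to compound 4 is expected to be a 1.9-fold higher number from compound 3 to compound 4 (0.27 log units; within the scatter), resting on compound 3 at 0.7 h and on an at least 1.9-fold higher number from compound 2 to compound 1 (0.28 log units; that floor lies within the scatter). Compound 4 is therefore estimated at 1.3 h, between 0.7 h and 2.5 h.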

Compound 4, half-life: > 1 h
Compound 4: a limit, no number (the forecaster's own chance of this, stated with the estimate: 50%); the middle value does not contradict the limit.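

In this assay compound 4 gives > 1 h, a limit and not a number. Methyl in place of isopropyl on the core of compound 3 gave an at least 1.4-fold higher number from compound 3 to compound 4 (0.15 log units; that floor lies within the scatter); this fits the earlier step but fixes the size of the change on neither core, and the step between the two limits, from compound 1 to compound 4, cannot be read. Whether the change is worth the same on both cores stays undecided: the same change on two cores in this assay, an at least 1.9-fold higher number (0.28 log units; that floor lies within the scatter) from compound 2 to compound 1 and an at least 1.4-fold higher number (0.15 log units; that floor lies within the scatter) from compound 3 to compound 4; the limit leaves it open whether they differ.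

The compounds shown leave open how ethyl or cyclopropyl would compare with methyl and isopropyl on that carbon. They also leave open whether the change would carry over to a core with a morpholine or a shorter chain.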